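The compounds below may be only part of what the source reports. "The series", "measured", "known", "first", "only" and "open" are said of these compounds alone.

Measured compounds:
compound 1 `COc1ccc2cc(C(C)c3nnc4n3N=C(c3ccc(C(F)(F)F)cc3)CS4)ccc2c1` – 6900 nM
compound 2 `CC(c1ccc(-c2ccccc2)c(F)c1)c1nnc2n1N=C(c1ccccc1)CS2` – 7400 nM

In a functional assay on MCF7 cells (Homo sapiens) for inhibition, read by sulforhodamine B assay, with a stated time of 72 h (a lower number here means a stronger inhibitor, a higher number a weaker inhibitor), compound 1 gives 6900 nM, the lower of the two numbers, though its gap to compound 2 lies within the scatter. Compound 3 `COc1ccc2cc(C(C)c3nnc4n3N=C(c3ccc(Br)cc3)CS4)ccc2c1` differs from compound 1 by bromo in place of trifluoromethyl on an aromatic carbon. Among the measured compounds shown here, no step between measured compounds is available that would guide this change, so the expectation for the step of a 1.0-fold higher number from compound 1 to compound 3 (0.01 log units; within the scatter) is that it stays within the scatter, in no clear direction. Compound 3 is therefore estimated at 7000 nM, with a range from 2500 nM to 20000 nM.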

Compound 3, half-maximal inhibitory concentration: 11500 nM
Compound 3: middle estimate off by 1.6-fold (0.22 log units), on the low side; low and high end bracket the measured number.
By their numbers in this assay, from the lowest: compounds 1, 2 and 3 (each within the scatter of the next).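

In this assay, replacing trifluoromethyl with bromo on the aromatic carbon gives a 1.7-fold higher number from compound 1 to compound 3 (0.22 log units; within the scatter). The change from 4-(trifluoromethyl)phenyl to 4-bromophenyl, with one heavy atom in place of four, therefore leaves the number within the scatter at this position. No measurement shown offers an explanation for this result. On these data alone, it remains open whether an amine or a carboxylic acid on this aromatic carbon would move the number beyond the scatter. As far as these compounds go, it is also open whether the same exchange would give a similar step in a compound that differs elsewhere from compound 1.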